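This account rests on a few compounds, and the source may have more. Where it says the series, first, only, none or still open, it means among the compounds named here.

Measured in a functional assay on MCF7 cells (Homo sapiens) for cytotoxicity, read by MTT assay, with a stated time of 24 h; a higher number here means a weaker inhibitor, a lower number a stronger inhibitor:
- compound 1 `CC(=O)Nc1ccc(Oc2cccc3c(NC(=O)Nc4cccc(C(F)(F)F)c4)cccc23)cc1`: 953 nM
- compound 2 `CC(=O)Nc1ccc(Oc2cccc3c(NC(=O)Nc4ccccc4)cccc23)cc1`: 953 nM
- compound 3 `O=C(Nc1ccc(Cl)c(C(F)(F)F)c1)Nc1cccc2c(Oc3ccc([N+](=O)[O-])cc3)cccc12`: 953 nM

Compound 3 stands level with the other two. Compound 4 `CC(=O)Nc1ccc(Oc2cccc3c(NC(=O)Nc4ccc(Cl)c(C(F)(F)F)c4)cccc23)cc1` differs from it by acetamido in place of nitro on an aromatic carbon, para to a large group: acetamido in place of nitro on an aromatic carbon.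

For the measured compounds named here, no measured step makes this exchange directly. Going by the values given here, the one measured single-place step, no change at the digits printed from compound 1 to compound 2 (within the scatter), concerns hydrogen in place of trifluoromethyl. Compound 3, with the 4-nitrophenoxy group, gives the same reading as compound 1, with the 4-acetamidophenoxy group, at 953 nM. No step beyond the scatter is therefore expected in this assay, in either direction.

The estimated step is a 1.0-fold lower number from compound 3 to compound 4 (0.00 log units; within the scatter). Compound 4 is expected at 950 nM, with an estimated range of 475 nM to 1900 nM.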

Compound 4, half-maximal inhibitory concentration: 953 nM
For compound 4 the middle estimate is 1.0-fold (0.00 log units) below the measured one; low and high end bracket the measured number.
By their numbers in this assay, from the lowest: compounds 1, 2, 3 and 4 (each within the scatter of the next).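

In this assay, for the compounds shown here, acetamido in place of nitro, para to a large group, gives no change at the digits printed from compound 3 to compound 4 (within the scatter) and is the first direct reading of this exchange. With acetamido held, chloro in place of hydrogen on an aromatic carbon reads no change at the digits printed from compound 1 to compound 4 (within the scatter) and 4-chloro-3-(trifluoromethyl)phenyl in place of phenyl reads no change at the digits printed from compound 2 to compound 4 (within the scatter) as well.

As far as these compounds go, whether an amine or a carboxylic acid at the place of nitro and acetamido would separate from these compounds in this assay stays open. No evidence on hand bears on the matching readings.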